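Fluoro to nitro on the aniline ring of compound 2

A few compounds are considered here, and "the series" means these few. Any claim that something is new, unique, unknown or untested is made for them only; others in the source may bear on it.

Two compounds have numbers in a functional assay on JAR cells (Homo sapiens) for inhibition, read by MTT assay, with a stated time of 72 h; a higher number here means a weaker inhibitor, a lower number a stronger inhibitor. Compound 1 `CCOC(=O)C1=C(Nc2ccccc2)S/C(=C\c2ccc([N+](=O)[O-])c(O)c2)C1=O` gives 12700 nM in this assay. Compound 2 `CCOC(=O)C1=C(Nc2ccc(F)cc2)S/C(=C\c2ccc[nH]2)C1=O` gives 15900 nM in this assay, the higher of the two numbers, though its gap to compound 1 lies within the scatter. Compound 3 `CCOC(=O)C1=C(Nc2ccc([N+](=O)[O-])cc2)S/C(=C\c2ccc[nH]2)C1=O` differs from compound 2 by nitro in place of fluoro on an aromatic carbon. Within the data shown here, no pair of measured compounds shows what this change does, so the step is expected to be small and of no sure direction. Compound 3 is therefore estimated at 13000 nM, between 5000 nM and 35000 nM, an expected step of a 1.2-fold lower number from compound 2 to compound 3 (0.09 log units; within the scatter).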

Compound 3, half-maximal inhibitory concentration: 15600 nM
Compound 3: middle estimate off by 1.2-fold (0.08 log units), on the low side; the measured number falls inside the stated range.
By their numbers in this assay, from the lowest: compounds 1, 3 and 2 (each within the scatter of the next).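

Among these compounds, the 4-fluorophenyl to 4-nitrophenyl exchange gives the first direct reading at this position: in this assay, nitro in place of fluoro gives a 1.0-fold lower number from compound 2 to compound 3 (0.01 log units; within the scatter). The two compounds cannot be told apart here, although nitro carries hydrogen-bond acceptors and fluoro none. No measurement at hand bears on why this is so. From the compounds shown here alone, whether an amine or a carboxylic acid on this aromatic carbon would give a number apart from these two stays open. So does whether the same exchange would read alike on the core of compound 1.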